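The source may report more compounds than this note shows. Statements on the series, on what has been measured and on what is new or still open speak of the compounds shown alone.

Compound 1 `CCCn1ccnc1/C=C/C(=O)/C=C/c1coc2ccccc2c1=O`: 2400 nM
Compound 2 `CC(C)n1ccnc1/C=C/C(=O)/C=C/c1coc2ccccc2c1=O`: 2300 nM
Compound 3 `CCCC(C)n1ccnc1/C=C/C(=O)/C=C/c1coc2ccccc2c1=O`: 3200 nM

These numbers come from a functional assay on PC-3 cells (Homo sapiens) for cytotoxicity, read by WST assay, with a stated time of 3 days; on this read-out lower numbers stand for stronger inhibition and higher numbers for weaker inhibition. The three compounds share one core and differ only in the group on an aromatic nitrogen. Compound 2, which carries isopropyl, cannot be told apart from the other two. The measurements show a 1.0-fold lower number from compound 1 to compound 2 (0.02 log units; within the scatter) and a 1.4-fold higher number from compound 2 to compound 3 (0.14 log units; within the scatter).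

Compound 4 `CCC(CC)n1ccnc1/C=C/C(=O)/C=C/c1coc2ccccc2c1=O` has not yet been measured. Its change is pentan-3-yl in place of isopropyl on an aromatic nitrogen.

The most useful precedent is the change from isopropyl to 1-methylbutyl, which also puts a larger group in this place and gave a 1.4-fold higher number from compound 2 to compound 3 (0.14 log units; within the scatter). The swap from propyl to 1-methylbutyl tells a similar story, with a 1.3-fold higher number from compound 1 to compound 3 (0.12 log units; within the scatter). Neither step rises above the noise, so in this assay no step beyond the scatter is expected, with at most a slight lean towards a higher number. Among the measured compounds shown here, this expectation rests on only three compounds, and none of them carries pentan-3-yl itself.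

The expected change is a 1.2-fold higher number from compound 2 to compound 4 (0.09 log units; within the scatter). Compound 4 is estimated at 2800 nM, with an expected range of 1500 nM to 5200 nM.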

Compound 4, half-maximal inhibitory concentration: 2900 nM
Beside the measured number, compound 4's estimate is 1.0-fold (0.02 log units) below it, within the range that was stated.
By their numbers in this assay, from the lowest: compounds 2, 1, 4 and 3 (each within the scatter of the next).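

In this assay, a larger group on the aromatic nitrogen still produces no change that can be told apart: pentan-3-yl in place of isopropyl gives a 1.3-fold higher number from compound 2 to compound 4 (0.10 log units; within the scatter). Pentan-3-yl also cannot be separated from the other two groups, with a 1.1-fold lower number from compound 3 to compound 4 (0.04 log units; within the scatter) and a 1.2-fold higher number from compound 1 to compound 4 (0.08 log units; within the scatter), so propyl, isopropyl, 1-methylbutyl and pentan-3-yl all give numbers within the scatter of one another in this set. Compound 4 also adds a second example of an ethyl group replacing a hydrogen on the saturated chain, and the two examples agree, so this small effect no longer rests on a single pair: the same change on two cores in this assay, a 1.4-fold higher number (0.14 log units; within the scatter) from compound 2 to compound 3 and a 1.2-fold higher number (0.08 log units; within the scatter) from compound 1 to compound 4, 1.2-fold (0.06 log units) apart, within the scatter of two such steps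

All four groups shown are plain saturated carbon groups without a ring, so it remains open whether an amine, a carboxylic acid or a hydroxyl group on the chain at this nitrogen would move the number beyond the scatter. As far as these compounds go, a much longer chain is equally open, and the flat result in this one cell assay says nothing about how these compounds would compare on other cells or in other tests.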